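The source may report more compounds than this note shows. Statements on the series, on what has been measured and on what is new or still open speak of the compounds shown alone.

Compound 3 `O=C(NCc1ccc(S(=O)(=O)c2cncc(C(F)(F)F)c2)cc1)N1Cc2ccncc2C1` shares its core with compound 1 `O=C(NCc1ccc(S(=O)(=O)c2ccccc2)cc1)NCc1cccnc1`. In an assay on isolated protein for inhibition of Nicotinamide phosphoribosyltransferase (Homo sapiens), read by mass spectrometry, with stated times of 15 min and 30 min (a higher number here means a weaker inhibitor, a lower number a stronger inhibitor), compound 3 gives 15 nM, sitting at the low end of the two measured numbers; compound 1 gives 19 nM, and the gap between the two is within the scatter, so neither can be called the stronger inhibitor. For compound 2 `O=S(=O)(c1ccccc1)c1ccc(CNS(=O)(=O)N2Cc3ccncc3C2)cc1` the reading is > 2000 nM, which is the limit of > 2000 nM in this assay, at which 1 of the 3 values shown sits, rather than a measured number. Compound 4 `O=C(NCc1ccc(S(=O)(=O)C2CCOCC2)cc1)N1Cc2ccncc2C1` has not yet been measured; it differs from compound 3 in one place, (oxan-4-yl in place of 5-(trifluoromethyl)pyridin-3-yl on a sulfonyl sulfur). Among the compounds with values here, no measured pair shows an exchange of this kind, so the size of the step is open; a modest weakening beyond the scatter is expected, as a 3.0-fold higher number from compound 3 to compound 4 (0.48 log units; beyond the scatter). Compound 4 is therefore estimated at 45 nM, within 12 nM to 200 nM.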

Compound 4, half-maximal inhibitory concentration: 26 nM
Estimate against measurement, compound 4: 1.7-fold (0.24 log units) above, within the range that was stated.
By their numbers in this assay, from the lowest: compounds 3, 1 and 4 (each within the scatter of the next). At a limit, above all of these: compound 2.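

In this assay the exchange gives a 1.7-fold higher number from compound 3 to compound 4 (0.24 log units; within the scatter), so on this sulfonyl sulfur a non-aromatic oxan-4-yl ring can stand in place of an aromatic ring without a change that can be told from the scatter. Within the data shown here, none of the earlier compounds carried a non-aromatic ring at this place. The data shown offer no explanation for this result. From the compounds shown here alone, whether any ring is needed here stays open: a methyl group or an amine on the sulfonyl sulfur would test that.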